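A Pyridinyl Amide in Place of the Methoxyphenyl Group

The source may report more compounds than this note shows. Statements on the series, on what has been measured and on what is new or still open speak of the compounds shown alone.

Compound 1 `COc1ccc2nc(C)cc(OC(C)C(=O)Nc3cc(C)cc(C)c3)c2c1`: in a toxicity assay on HepG2 cells (Homo sapiens) for inhibition, read by CellTiter-Glo, with a stated time of 48 h (a lower number here means a stronger inhibitor, a higher number a weaker inhibitor), compound 1 gives 39800 nM.
Compound 2 `COc1ccc2nc(C)cc(OC(C)(C)C(=O)Nc3cc(C)cc(C)c3)c2c1`: compound 2 gives > 100000 nM, which is a limit of the assay and not a number.
Compound 3 `COc1cccc(NC(=O)COc2cc(C)nc3ccc(OC)cc23)c1`: compound 3 gives > 100000 nM, likewise a limit and not a number.

Only compound 1 carries a measured number; compound 3 stands at the limit, as the limit of > 100000 nM in this assay, at which 2 of the 3 values shown sit, records. Among the compounds with values here, the single measured step, an at least 2.5-fold higher number from compound 1 to compound 2 (0.40 log units; beyond the scatter), concerns methyl in place of hydrogen on a saturated chain carbon and ends at the same limit. Compound 4 `COc1ccc2nc(C)cc(OCC(=O)Nc3ccccn3)c2c1` differs from compound 3 at a different place: pyridin-2-yl in place of 3-methoxyphenyl on an amide-type nitrogen. Within the data shown here, no measured step touches an exchange on the amide-type nitrogen, so the step from compound 1 to compound 2 does not carry over, and with compound 3 at the limit no direction can be read from the numbers. A step in this assay beyond the scatter is not expected in either direction. Compound 4 is therefore expected to give 100000 nM in this assay, within 30000 nM to 300000 nM. The expected step is a number no higher from compound 3 to compound 4 (the limit leaves the size open), and a limit rather than a number is the likely outcome.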

Compound 4, half-maximal inhibitory concentration: > 100000 nM
Compound 4 gave a limit, no number (the forecaster's own chance of this, stated with the estimate: 60%); the middle value sits exactly at the limit.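

Within the data shown here, compound 3 and compound 4 both stand at a limit in this assay, and no step between them can be read. The compounds shown leave open what pyridin-2-yl in place of 3-methoxyphenyl on an amide-type nitrogen does to the number, and the values gather at one limit: the limit of > 100000 nM in this assay, at which 3 of the 4 values shown sit.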